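Cyclopentyl in place of isopropyl: expected outcome for compound 3

The compounds below may be only part of what the source reports. "The series", "measured", "known", "first", "only" and "open" are said of these compounds alone.

Two compounds of the series carry a number in a functional assay (cardiac atrium) for agonist activity, with Cavia porcellus as the target (on this read-out higher numbers stand for an effect only at larger amounts of compound and lower numbers for an effect already at smaller amounts), so far. Compound 1 `CC1=NC(C)=C([N+](=O)[O-])C(c2ccccn2)/C1=C(\O)OC1CCCC1` gives 19800 nM in this assay. For the measured compounds named here, compound 2 `CC1=NC(C)=C([N+](=O)[O-])C(c2cccnc2)/C1=C(\O)OC(C)C` gives 28500 nM in this assay, the highest of the two numbers, with compound 1 as its nearest neighbour at a gap that stays within the scatter; the two compounds differ in more than one place, so their pair gives no single step to read, and the two values show only that both compounds act in the same range of concentrations.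

Compound 3 `CC1=NC(C)=C([N+](=O)[O-])C(c2cccnc2)/C1=C(\O)OC1CCCC1` has not been measured in this assay. It is reached from compound 2 by one change, (cyclopentyl in place of isopropyl on an oxygen on an unsaturated carbon). Going by the values given here, no measured pair of the series isolates this change, so nothing in the data fixes its size or direction. Compound 1 already carries cyclopentyl and stands within the scatter of compound 2, which argues against a large shift. The step of a 1.3-fold lower number from compound 2 to compound 3 (0.11 log units; within the scatter) is therefore expected to stay within the scatter, with no clear direction. For compound 3 the expected value in this assay is 22000 nM, within a range from 8000 nM to 60000 nM.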

Compound 3, half-maximal effective concentration: 3280 nM
Compound 3: middle estimate off by 6.7-fold (0.83 log units), on the high side; measured number outside the range, below it.
By their numbers in this assay, from the lowest: compound 3; then compounds 1 and 2 (each within the scatter of the next).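

With pyridin-3-yl held constant, cyclopentyl in place of isopropyl on an oxygen on an unsaturated carbon gives an 8.7-fold lower number from compound 2 to compound 3 (0.94 log units; beyond the scatter) in this assay and thus shows that this position responds to the change, which the earlier pair, differing in more than one place, could not show. With cyclopentyl held constant, pyridin-3-yl in place of pyridin-2-yl on a saturated ring carbon gives a 6.0-fold lower number from compound 1 to compound 3 (0.78 log units; beyond the scatter) and shows that the second position responds as well, so the closeness of the first two numbers hid two separate effects on the read-out. No measurement at hand accounts for either step.

Going by these compounds, it remains open whether the gain from cyclopentyl also holds with pyridin-2-yl on the saturated ring carbon, and whether it depends on the ring itself or only on the larger carbon count, a question that cyclobutyl, cyclohexyl or an open chain such as pentan-3-yl could address. The compounds shown also leave open how far the second position tolerates other rings, such as pyridin-4-yl or phenyl.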